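Demethylation of an Aryl Methyl Ether in a Pyrazole Urea Series

This account rests on a few compounds, and the source may have more. Where it says the series, first, only, none or still open, it means among the compounds named here.

Four compounds built around a diaryl urea attached to a pyrazole bearing a pyridyl group were considered in a functional assay on 786-0 cells (Homo sapiens) for inhibition, read by sulforhodamine B assay, with a stated time of 48 h; on this read-out lower numbers stand for stronger inhibition of growth and higher numbers for weaker inhibition of growth. Compound 1 `COc1cc(-c2nn(-c3cccc(NC(=O)Nc4cc(C(F)(F)F)cc(C(F)(F)F)c4)c3)cc2-c2ccncc2)ccc1Cl` carries a 4-chloro-3-methoxyphenyl group and a bis(trifluoromethyl)phenyl urea; in this assay compound 1 gives 2020 nM. Compound 2 `COc1cc(-c2nn(-c3cccc(NC(=O)Nc4ccc(Cl)c(Cl)c4)c3)cc2-c2ccncc2)ccc1Cl` differs from compound 1 in the urea end, where a dichlorophenyl group stands; the difference between the two cores is not broken down here. In this assay compound 2 gives 4470 nM, and compound 1 stands at the lower number of the two, with the gap lying beyond the scatter.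

Compound 3 `O=C(Nc1cccc(-n2cc(-c3ccncc3)c(-c3ccc(Cl)c(O)c3)n2)c1)Nc1ccc(Cl)c(Cl)c1` is compound 2 with the methyl ether opened. In this assay compound 3 gives a limit rather than a number, > 32500 nM. The change, (hydrogen in place of methyl on an oxygen on an aromatic ring), therefore produced a step of an at least 7.2-fold higher number from compound 2 to compound 3 (0.86 log units; beyond the scatter), which is reported as an at-least value because of the limit of > 32500 nM in this assay, at which 1 of the 3 values shown sits.

Compound 4 `O=C(Nc1cccc(-n2cc(-c3ccncc3)c(-c3ccc(Cl)c(O)c3)n2)c1)Nc1cc(C(F)(F)F)cc(C(F)(F)F)c1` has not yet been measured. It arises from compound 1 by hydrogen in place of methyl on an oxygen on an aromatic ring, the same change that turned compound 2 into compound 3, at the same place. Given that compound 2 moved by an at least 7.2-fold higher number from compound 2 to compound 3 (0.86 log units; beyond the scatter), the step for compound 4 is expected to be of comparable size, a 7.9-fold higher number from compound 1 to compound 4 (0.90 log units; beyond the scatter). Compound 4 is accordingly estimated to give 16000 nM in this assay, within a range from 6000 nM to 40000 nM, with a real chance that only a limit is reported.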

Compound 4, concentration for total growth inhibition: 3160 nM
Compound 4: the middle estimate sits 5.1-fold (0.70 log units) above what was measured; measured number below the stated range.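

In this assay, putting hydroxy in place of methoxy on the core of compound 1 gives a 1.6-fold higher number from compound 1 to compound 4 (0.19 log units; within the scatter), so on this core the two compounds cannot be told apart. The change therefore did not carry over at the same size from one urea end to the other, and its outcome in this pair differs from that in the pair with the dichlorophenyl urea: the same change on two cores in this assay, an at least 7.2-fold higher number (0.86 log units; beyond the scatter) from compound 2 to compound 3 and a 1.6-fold higher number (0.19 log units; within the scatter) from compound 1 to compound 4, at least 4.6-fold (0.66 log units) apart, beyond the scatter of two such steps

Two pairs set no rule for the series and give no reason for the difference, and the full size of the larger step stays unknown, for it rests on a value that is a limit and not a number: the limit of > 32500 nM in this assay, at which 1 of the 4 values shown sits.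

The compounds shown leave open how the same change would read on other urea ends, such as a phenyl ring bearing a single fluorine or a methyl group, and so whether either of the two pairs is the more typical. Also open, from the compounds shown here alone, is how this assay would respond to a longer chain on that oxygen, such as an ethyl or a propyl ether, or to an amine standing in place of the hydroxy group.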